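Cytotoxicity limits in the series and one expected value

The source may report more compounds than this note shows. Statements on the series, on what has been measured and on what is new or still open speak of the compounds shown alone.

Measured compounds:
compound 1, `O=c1[nH]c2ccc(Cl)cc2n1Cc1c(F)cccc1F`
compound 2, `O=c1[nH]c2ccc(Cl)cc2n1Cc1cc(F)cc(F)c1`
compound 3, `O=c1[nH]c2cc(F)c(Cl)cc2n1Cc1cc(F)cc(F)c1`

In an ADME assay on MT4 cells (Homo sapiens) for cytotoxicity (a higher number here means that more compound is tolerated, a lower number that less compound is tolerated), compound 1 reaches only a limit, > 424000 nM. Compound 2 also stops at a limit in this assay, > 424000 nM. Compound 3 likewise gives no number but a limit, > 400000 nM. Two of the three values sit at the limit of > 424000 nM in this assay, at which 2 of the 3 values shown sit, and one at the limit of > 400000 nM in this assay, at which 1 of the 3 values shown sits. The change from compound 2 to compound 3 is fluoro in place of hydrogen on an aromatic carbon. The resulting step that the two limits leave unreadable from compound 2 to compound 3 cannot be sized from two limits. Compound 1 and compound 2 have the same atoms joined differently; the difference between the two cores is not broken down here.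

Compound 4, `O=c1[nH]c2cc(F)c(Cl)cc2n1Cc1c(F)cccc1F`, has not been measured. It differs from compound 1 by fluoro in place of hydrogen on an aromatic carbon, the same change as that between compound 2 and compound 3. Since both ends of the measured step lie at limits, nothing indicates a marked shift. For compound 4 the expected step is a step that the limit leaves unreadable from compound 1 to compound 4, judged small. Compound 4 is thus expected to give about 500000 nM, with a likely range from 300000 nM to 900000 nM, and most probably again only a limit.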

Compound 4, half-maximal cytotoxic concentration: 267000 nM
Compound 4: middle estimate off by 1.9-fold (0.27 log units), on the high side; measured number below the stated range.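

In this assay, fluoro in place of hydrogen on an aromatic carbon of the core of compound 1 gives an at least 1.5-fold lower number from compound 1 to compound 4 (0.20 log units; that floor lies within the scatter), so the data show a lower number of unknown full size, but they do not establish a change beyond the scatter. On the other core, compound 3 stops at a limit: the limit of > 400000 nM in this assay, at which 1 of the 4 values shown sits. Compound 2 also stops at a limit, the step between these two cannot be read, and the series therefore does not show whether the change has the same size on both cores.

Among these compounds, with compound 4 as the only exact number in this assay, the size of any effect of this change on either core stays open, as does the result with a pair of readable values. Also open, from the compounds shown here alone, is what an amine, a carboxylic acid or a longer chain would give in place of the fluoro group, on an aromatic carbon ortho to a chloro group.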